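The source may report more compounds than this note shows. Statements on the series, on what has been measured and on what is new or still open speak of the compounds shown alone.

Compound 3 `CSc1ncnc2c1c(-c1ccccc1)cn2[C@@H]1O[C@H](CO)[C@@H](O)[C@H]1O` gives > 100000 nM in an ADME assay on MRC5 cells (Homo sapiens), read by MTT assay, with a stated time of 72 h (a higher number here means a weaker inhibitor, a lower number a stronger inhibitor), and this is a limit, not a number. Compound 1 `C#Cc1cn([C@@H]2O[C@H](CO)[C@@H](O)[C@H]2O)c2ncnc(OC)c12` gives > 100000 nM, also a limit. Compound 2 `CSc1ncnc2c1c(-c1ccoc1)cn2[C@@H]1O[C@H](CO)[C@@H](O)[C@H]1O` gives > 100000 nM, likewise a limit. For the measured compounds named here, the series so far therefore stands at the limit of > 100000 nM in this assay, at which 3 of the 3 values shown sit.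

The next change leads to compound 4 `C#Cc1cn([C@@H]2O[C@H](CO)[C@@H](O)[C@H]2O)c2ncnc(SC)c12`: ethynyl in place of phenyl on an aromatic carbon. In short, ethynyl replaces phenyl on an aromatic carbon of the five-membered aromatic ring.

Going by the values given here, the only measured step bearing on this carbon is a step that the two limits leave unreadable from compound 2 to compound 3. It offers no size to carry over, so no step beyond the scatter can be derived for this assay. A reading at the same limit remains the likeliest outcome, with a smaller chance of a measurable number on the stronger side. The expected change is an at least 1.2-fold lower number from compound 3 to compound 4 (0.09 log units; that floor lies within the scatter), which would not be a step beyond the scatter. For compound 4 the estimated value is 80000 nM, with an expected range from 20000 nM to 100000 nM.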

Compound 4, half-maximal inhibitory concentration: > 100000 nM
Compound 4 was reported as a limit; the forecaster's own chance of this, stated with the estimate: 65%; middle value at least 1.2-fold (0.09 log units) from the limit.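

In this assay compound 4 gives > 100000 nM, a limit. For the compounds shown here, no step to compound 4 from compound 1, compound 2 or compound 3 can be read. The compounds shown leave open which change to the shared core, if any, would give a measurable number in this assay.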